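Can a Larger Group Shift a Flat Pair?

A few compounds are considered here, and "the series" means these few. Any claim that something is new, unique, unknown or untested is made for them only; others in the source may bear on it.

In a functional assay on MCF7 cells (Homo sapiens) for cytotoxicity, read by MTT assay, with a stated time of 72 h (a higher number here means a weaker inhibitor, a lower number a stronger inhibitor), compound 1 `O=C(CSC(=S)N[C@H]1CCOC1=O)Nc1ccc(Cl)cc1` gives 50300 nM and compound 2 `CCOC(=O)c1ccc(NC(=O)CSC(=S)N[C@H]2CCOC2=O)cc1` gives 60300 nM. The step between them, a 1.2-fold higher number from compound 1 to compound 2 (0.08 log units; within the scatter), is the only measured one, and it lies within the scatter. Compound 3 `O=C(CSC(=S)N[C@H]1CCOC1=O)Nc1ccc(C(=O)/C=C/c2cccc(Cl)c2)cc1` carries 2-(3-chlorophenyl)ethenyl in place of ethoxy on a carbonyl carbon. Within the data shown here, no measured compound holds this group, so that step offers only weak guidance, and a modest move towards a lower number in this assay is a tentative expectation. The estimated step is a 2.7-fold lower number from compound 2 to compound 3 (0.44 log units; beyond the scatter). For compound 3 the expected value is 22000 nM, within an estimated range of 5000 nM to 70000 nM.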

Compound 3, half-maximal inhibitory concentration: 11600 nM
The estimate for compound 3 lay 1.9-fold (0.28 log units) above the measured number, within the range that was stated.
By their numbers in this assay, from the lowest: compound 3; then compounds 1 and 2 (each within the scatter of the next).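

In this assay, 2-(3-chlorophenyl)ethenyl in place of ethoxy on a carbonyl carbon gives a 5.2-fold lower number from compound 2 to compound 3 (0.72 log units; beyond the scatter) and moves the number beyond the scatter, which the earlier pair, compounds 1 and 2, did not do. This carbonyl carbon is therefore a place where a change can shift the number. No measurement shown explains this step.

Going by these compounds, the chlorine, the double bond and the aromatic ring all enter together, so their separate shares remain open. Whether an amine in place of that chlorine would keep the step is also unknown.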